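The source may report more compounds than this note shows. Statements on the series, on what has been measured and on what is new or still open speak of the compounds shown alone.

Compound 1 `CCOC(=O)NC(=O)NC1=CS(=O)(=O)O[C@@]12[C@@H](CO[Si](C)(C)C(C)(C)C)O[C@@H](n1cc(C)c(=O)n(C)c1=O)[C@@H]2O[Si](C)(C)C(C)(C)C`: 14000 nM
Compound 2 `Cc1cn([C@@H]2O[C@H](CO[Si](C)(C)C(C)(C)C)[C@@]3(OS(=O)(=O)C=C3NC(=O)c3ccccc3)[C@H]2O[Si](C)(C)C(C)(C)C)c(=O)n(C)c1=O`: 9700 nM
Compound 3 `Cc1cn([C@@H]2O[C@H](CO[Si](C)(C)C(C)(C)C)[C@@]3(OS(=O)(=O)C=C3NCCC(=O)O)[C@H]2O[Si](C)(C)C(C)(C)C)c(=O)n(C)c1=O`: 34000 nM

All three share the core of compound 1 and differ only in the group carried on the amine nitrogen whose other neighbour is a double-bonded ring carbon. In a functional assay on HEL cells (Homo sapiens) (on this read-out higher numbers stand for lower toxicity in this test and lower numbers for higher toxicity in this test), compound 1 gives 14000 nM, the second highest of the three numbers. Its nearest neighbour is compound 2 with 9700 nM; the step of a 1.4-fold lower number from compound 1 to compound 2 (0.16 log units; within the scatter) stays within the scatter. Compound 3, with 34000 nM, sits furthest off, and a 2.4-fold higher number from compound 1 to compound 3 (0.39 log units; beyond the scatter). Between the other two, a 3.5-fold higher number from compound 2 to compound 3 (0.54 log units; beyond the scatter).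

Compound 4 `Cc1cn([C@@H]2O[C@H](CO[Si](C)(C)C(C)(C)C)[C@@]3(OS(=O)(=O)C=C3NCC(=O)C(=O)N3CCC3)[C@H]2O[Si](C)(C)C(C)(C)C)c(=O)n(C)c1=O` is not yet measured. Its difference from compound 1 is (((azetidin-1-yl)carbonyl)carbonyl)methyl in place of (ethoxycarbonyl)carbamoyl on an amine nitrogen. The two measured steps that bear on this change are those leaving compound 1 toward compounds 2 and 3, since both also swap the group on this amine nitrogen: one within the scatter, the other modest and upward. Neither introduces anything resembling the entering group, so the guide is loose. A small step, if any, is expected, and a 1.2-fold higher number from compound 1 to compound 4 (0.08 log units; within the scatter) is the expected outcome. Compound 4 is accordingly estimated at 17000 nM, with an expected range from 7000 nM to 40000 nM.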

Compound 4, half-maximal cytotoxic concentration: 84400 nM
Estimate against measurement, compound 4: 5.0-fold (0.70 log units) below; the measured number lies above the stated range.
By their numbers in this assay, from the lowest: compounds 2 and 1 (each within the scatter of the next); then compound 3; then compound 4.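

In this assay, the amine nitrogen whose other neighbour is a double-bonded ring carbon proves able to shift the number well beyond the scatter: the (((azetidin-1-yl)carbonyl)carbonyl)methyl group gives a 6.0-fold higher number from compound 1 to compound 4 (0.78 log units; beyond the scatter), a larger step than either earlier change from compound 1. The same group also stands clear of the two other substituents, with a 2.5-fold higher number from compound 3 to compound 4 (0.39 log units; beyond the scatter) and an 8.7-fold higher number from compound 2 to compound 4 (0.94 log units; beyond the scatter), so compound 4 now has the highest number in the series, and its steps to all three others lie beyond the scatter; on this read-out, that marks the lowest toxicity in this test among the four compounds. No measurement shown here accounts for the size of this step.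

As far as these compounds go, it remains open whether the step belongs to the azetidine ring or to the chain with its two carbonyls; a pyrrolidine amide or a dimethylamide on the same chain would bear on that. Also open, from the compounds shown here alone, is where a simple primary amine at the end of a short chain on this nitrogen would fall in this assay.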